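The source may hold more compounds than are shown below. What is called first, only, known or untested is meant among the compounds shown, and "the series" means these compounds.

Of the compounds shown here, two have been measured in an assay on HeLa cells for displacement of a labelled ligand from adenosine receptor A3 (Homo sapiens), read by scintillation counting, with a stated time of 180 min, tested at 10 uM; a lower number here means less inhibition, a higher number more inhibition at the concentration tested (going by the name of the read-out). Compound 1 `COC(=O)/C(C#N)=C/c1cccc(OC)c1O` gives 45% in this assay. Compound 2 `N=c1oc2ccc(Br)cc2cc1C(=O)NCCO` gives 0% in this assay, the lowest of the two numbers, with compound 1 standing a good deal higher, a gap beyond the scatter. Compound 3 `N=c1oc2ccc(Br)cc2cc1C(=O)NCC(O)CO` has not yet been measured. It differs from compound 2 by a single change: hydroxymethyl in place of hydrogen on a saturated chain carbon bound to an oxygen on a saturated carbon and a saturated chain carbon. No measured pair among these compounds shows what this change does, so the expectation rests on compound 2 alone, whose value of 0% leaves little room for a downward move. The change is expected to bring no step beyond the scatter, and a number 3 percentage points higher from compound 2 to compound 3 (within the scatter) is the estimated step. Compound 3 is therefore expected to give 3% in this assay, within a range from -8% to 15%.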

Compound 3, a percentage reported as inhibition, at one concentration (the size of the read-out at that concentration, not a potency): 10%
The estimate for compound 3 lay 7 percentage points below the measured number; measured number inside the range.
By their numbers in this assay, from the lowest: compounds 2 and 3 (each within the scatter of the next); then compound 1.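

Hydroxymethyl in place of hydrogen on this saturated chain carbon gives, in this assay, a number 10 percentage points higher from compound 2 to compound 3 (within the scatter) and this is the first measured pair to speak to this place on the chain. Going from 2-hydroxyethyl to 2,3-dihydroxypropyl therefore leaves compounds 2 and 3 indistinguishable in this read-out, and with the extra hydroxymethyl, with its hydrogen-bond donor and acceptor, the number stays level within the scatter. Nothing measured here bears on why the two compounds read alike.

Open, as far as these compounds go, is whether an amine or a carboxylic acid in place of this hydroxymethyl, or a longer chain, would give a number beyond the scatter of compound 2. Also open, from the compounds shown here alone, is whether any group at this place can bring the shared core of compounds 2 and 3 close to compound 1.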